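Epoxy Ketone in Place of an Amide on a Hexylphenyl Core

The source may hold more compounds than are shown below. What is called first, only, known or untested is meant among the compounds shown, and "the series" means these compounds.

Measured compounds:
compound 1 `C=CC(=O)c1ccc(CCCCCCCC)cc1`, 21400 nM
compound 2 `C/C=C/C(=O)Nc1ccc(CCCCCC)cc1`, > 100000 nM

In an assay on isolated protein for displacement of a labelled ligand from thyroid hormone receptor alpha (Homo sapiens), read by fluorescence polarization (on this read-out higher numbers stand for weaker inhibition and lower numbers for stronger inhibition), compound 1 gives 21400 nM. For compound 2 the assay reports only a limit, > 100000 nM, which is the limit of > 100000 nM in this assay, at which 1 of the 2 values shown sits; compound 2 therefore stands at the weak end of the two values shown, with no number of its own.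

Compound 3 `CCCCCCc1ccc(C(=O)C2CO2)cc1` is not yet measured. It differs from compound 2 by (oxiran-2-yl)carbonyl in place of ((prop-1-en-1-yl)carbonyl)amino on an aromatic carbon, on an aromatic carbon of a six-membered aromatic ring of carbon only, para to a hexyl group. Within the data shown here, no measured pair shows this change, so the step in this assay is an expectation only: a move toward stronger inhibition is expected, its size uncertain since compound 2 has only a limit. Compound 3 is estimated at 50000 nM, in a range from 15000 nM to 150000 nM, which would mean an expected step of an at least 2.0-fold lower number from compound 2 to compound 3 (0.30 log units; that floor lies within the scatter).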

Compound 3, half-maximal inhibitory concentration in the thyroid hormone receptor alpha assay: 33200 nM
For compound 3 the middle estimate is 1.5-fold (0.18 log units) above the measured one; low and high end bracket the measured number.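

On the aromatic carbon para to a hexyl group, (oxiran-2-yl)carbonyl in place of ((prop-1-en-1-yl)carbonyl)amino brings a measurable number in the thyroid hormone receptor alpha assay, with an at least 3.0-fold lower number from compound 2 to compound 3 (0.47 log units; beyond the scatter). Compound 2 has only a limit there, > 100000 nM, so the full size of this step cannot be read. In a physicochemical assay for solubility, in phosphate buffer (on this read-out lower numbers stand for lower solubility and higher numbers for higher solubility), compound 2 gives 42000 nM and compound 3 gives 204000 nM there. The same change also goes with higher solubility in the physicochemical assay: the measured solubility of compound 2, 42000 nM, and of compound 3, 204000 nM, a 4.9-fold higher number (0.69 log units; beyond the scatter)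

Going by these compounds, what stays open is whether the three-membered ring or the carbonyl carries the step in the thyroid hormone receptor alpha assay, a question that a cyclopropyl ketone, with carbon in place of the ring oxygen, would address. On these data alone, it is also open whether a carboxylic acid at this position, or a longer chain in place of the hexyl group, would keep both changes.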